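This account rests on a few compounds, and the source may have more. Where it says the series, first, only, none or still open, it means among the compounds named here.

Compound 2 `Oc1cccc(-c2cc(-c3cccs3)nc(-c3ccccc3Cl)c2)c1` is the lower of the two numbers recorded so far in a functional assay on DU-145 cells (Homo sapiens) for cytotoxicity, read by CCK-8 assay and cell counting, with a stated time of 2 days (on this read-out lower numbers stand for stronger inhibition and higher numbers for weaker inhibition), where compound 2 gives 1700 nM. Compound 1 `Oc1ccc(-c2cc(-c3cccs3)nc(-c3ccccc3Cl)c2)cc1` gives 4190 nM, and the move a 2.5-fold lower number from compound 1 to compound 2 (0.39 log units; beyond the scatter) came with the change to 3-hydroxyphenyl in place of 4-hydroxyphenyl. Compound 3 `Oc1cccc(-c2cc(-c3ccco3)nc(-c3ccccc3Cl)c2)c1` differs from compound 2 in another place: furan-2-yl in place of thiophen-2-yl on an aromatic carbon. Among the compounds with values here, no measured step touches this swap of one five-membered ring for another, so nothing here argues for a change beyond the scatter. Compound 3 is therefore expected to land near 1800 nM, within 700 nM to 4800 nM, an expected step of a 1.1-fold higher number from compound 2 to compound 3 (0.02 log units; within the scatter).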

Compound 3, half-maximal inhibitory concentration: 1630 nM
Estimate against measurement, compound 3: 1.1-fold (0.04 log units) above; low and high end bracket the measured number.
By their numbers in this assay, from the lowest: compounds 3 and 2 (each within the scatter of the next); then compound 1.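

At this position, next to the ring nitrogen, furan-2-yl in place of thiophen-2-yl gives a 1.0-fold lower number from compound 2 to compound 3 (0.02 log units; within the scatter) in this assay. So, on this read-out, this carbon accepts either five-membered ring, with oxygen or with sulfur, without a change that can be told from the scatter. No further data bear on this result.

Going by these compounds, whether a phenyl ring or an amine on this carbon would keep the number in this range remains open. So does whether furan-2-yl would give the same result alongside 4-hydroxyphenyl.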